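Adding a Second Chloro to the Phenyl Ring of Compound 2

This account rests on a few compounds, and the source may have more. Where it says the series, first, only, none or still open, it means among the compounds named here.

Compound 2 `Clc1cccc(-c2nnnn2Cc2cccnc2)c1` stands at the low end of the two numbers recorded so far: in an in vitro functional assay on 1321-N1 cells for antagonist activity at P2X purinoceptor 7 (Homo sapiens), read by FLIPR and calcium flux (on this read-out lower numbers stand for stronger inhibition and higher numbers for weaker inhibition), compound 2 gives 7940 nM. Its nearest neighbour, compound 1 `Clc1ccccc1-c1nnnn1Cc1cccnc1`, gives 15800 nM in this assay, and the two numbers lie within the scatter of one another, so nothing can be read into their difference. Compound 3 `Clc1ccc(Cl)c(-c2nnnn2Cc2cccnc2)c1` has not yet been measured in this assay. It carries chloro in place of hydrogen on an aromatic carbon, that is, chloro in place of hydrogen on an aromatic carbon, so that compound 3 bears two chloro groups where compound 2 bears one. Within the data shown here, no step between measured compounds exists to guide the expectation. The step of a 1.8-fold lower number from compound 2 to compound 3 (0.25 log units; within the scatter) is expected to be a modest gain, close to the edge of the scatter. Compound 3 is therefore expected to give 4500 nM in this assay, within a range of 1500 nM to 13000 nM.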

Compound 3, half-maximal inhibitory concentration: 15800 nM
The estimate for compound 3 lay 3.5-fold (0.55 log units) below the measured number; the measured number lies above the stated range.
By their numbers in this assay, from the lowest: compounds 2, 1 and 3 (each within the scatter of the next).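

Chloro in place of hydrogen on an aromatic carbon, ortho to a large group and para to a chloro group, gives a 2.0-fold higher number from compound 2 to compound 3 (0.30 log units; within the scatter) in this assay, so on compound 2 this change has no effect that can be told from the scatter. The same kind of change read from the other singly chlorinated compound gives no change at the digits printed from compound 1 to compound 3 (within the scatter), so both steps into compound 3 lead to the same conclusion: a further chloro on this ring does not separate the compounds in this series. No measurement shown here bears on why these values stand as they do.

As far as these compounds go, it remains open whether an amine, a methoxy group or a carboxylic acid at this position would give a step beyond the scatter. From the compounds shown here alone, it is also open whether any change to the phenyl ring can move these compounds clearly from one another.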